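The compounds below may be only part of what the source reports. "The series", "measured", "known", "first", "only" and "open" are said of these compounds alone.

Measured so far in an ADME assay for permeability, using PAMPA, with a stated time of 4 h, at pH 5.5; a lower number here means that the compound crosses the layer more slowly, a higher number that the compound crosses the layer faster
- compound 1 `NCCCCN(C[C@H]1Cc2ncccc2CN1)[C@H]1CCCc2cccnc21` gives 17 nm/s
- compound 2 `CN(C[C@H]1Cc2ncccc2CN1)[C@H]1CCCc2cccnc21` gives 460 nm/s
- compound 3 `NC/C=C/CN(C[C@H]1Cc2ncccc2CN1)[C@H]1CCCc2cccnc21` gives 2 nm/s

Compound 3 has the lowest of these three numbers, with an 8.5-fold lower number from compound 1 to compound 3 (0.93 log units; beyond the scatter) and a 230-fold lower number from compound 2 to compound 3 (2.36 log units; beyond the scatter) on record. The next compound, compound 4 `NC(=O)NCCCCN(C[C@H]1Cc2ncccc2CN1)[C@H]1CCCc2cccnc21`, has not yet been measured. The structural change is 3-ureidopropyl in place of 3-aminoprop-1-en-1-yl on a saturated chain carbon bound to an amine nitrogen and in words 3-ureidopropyl sits in place of 3-aminoprop-1-en-1-yl on a saturated chain carbon bound to an amine nitrogen.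

Going by the values given here, no measured compound carries the 3-ureidopropyl group, so no step measures this change directly. The nearest guide is compound 1, whose 3-aminopropyl group also has a propyl chain, and its modest step was an 8.5-fold lower number from compound 1 to compound 3 (0.93 log units; beyond the scatter) in the data. Compound 2 has only hydrogen at this place, and its large step of a 27-fold higher number from compound 1 to compound 2 (1.43 log units; beyond the scatter) makes it a poor guide for a compound that keeps a chain. A modest rise is therefore expected, and the estimated step is a 7.5-fold higher number from compound 3 to compound 4 (0.88 log units; beyond the scatter) for now. For compound 4 the estimated value is 15 nm/s with an expected range from 3 nm/s to 80 nm/s until the measurement arrives.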

Compound 4, apparent permeability: 7 nm/s
Estimate against measurement, compound 4: 2.1-fold (0.33 log units) above, and the stated range covers the measured number.
By their numbers in this assay, from the lowest: compound 3; then compound 4; then compound 1; then compound 2.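

In this assay, carbamoyl in place of hydrogen on an amine nitrogen gives a 2.4-fold lower number from compound 1 to compound 4 (0.39 log units; beyond the scatter) while the propyl chain stays the same, so changing only the group carried by that chain already shifts the number beyond the scatter. The 3-ureidopropyl group also leaves a 66-fold lower number from compound 2 to compound 4 (1.82 log units; beyond the scatter) and gives a 3.5-fold higher number from compound 3 to compound 4 (0.54 log units; beyond the scatter) against the unsaturated chain, which places all three chain-bearing compounds shown well below the one with hydrogen on the saturated chain carbon bound to an amine nitrogen. No measurement at hand explains these differences.

Going by these compounds, it remains open whether an acetamide or a carboxylic acid in place of the 3-ureido group would give a number closer to that of compound 2. A longer chain carrying the same 3-ureido group also remains an open case.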